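Adding one fluoro group to compound 2

This account rests on a few compounds, and the source may have more. Where it says the series, first, only, none or still open, it means among the compounds named here.

Measured in a functional assay on DU-145 cells (Homo sapiens) for cytotoxicity, read by MTT assay; a lower number here means a stronger inhibitor, a higher number a weaker inhibitor:
Compound 1 `COc1cc2ncnc(Nc3cc(O)[nH]n3)c2cc1OC`: < 100000 nM (a limit)
Compound 2 `COc1cc2ncnc(Nc3cc(-c4ccccc4)[nH]n3)c2cc1OC`: < 100000 nM (a limit)

The result for compound 2 is < 100000 nM, which is a limit and not a number. Compound 3 `COc1cc2ncnc(Nc3cc(-c4ccc(F)cc4)[nH]n3)c2cc1OC` differs from compound 2 in a single place, with fluoro in place of hydrogen on an aromatic carbon.

For the measured compounds named here, only one measured step is available, a step that the two limits leave unreadable from compound 1 to compound 2. It is a different swap, phenyl in place of hydroxy, and it offers no size to carry over. The remaining evidence is the limit of < 100000 nM in this assay, at which 2 of the 2 values shown sit. No step beyond the scatter can therefore be expected in this assay, and neither direction is favoured.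

The expected step is a step that the limit leaves unreadable from compound 2 to compound 3. For compound 3 the estimated value is 30000 nM, with an expected range from 6000 nM to 100000 nM.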

Compound 3, half-maximal inhibitory concentration: < 100000 nM
Compound 3 was reported as a limit; the forecaster's own chance of this, stated with the estimate: 60%; the middle value lies beyond the limit too.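

In this assay, for the compounds shown here, compound 1, compound 2 and compound 3 are each reported only as a limit, so no step between them can be read. The compounds shown leave open how strongly each one acts on these cells, and whether going from phenyl to 4-fluorophenyl changes that at all.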